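Rat Clearance Across Three Related Compounds

A few compounds are considered here, and "the series" means these few. Any claim that something is new, unique, unknown or untested is made for them only; others in the source may bear on it.

Measured compounds:
compound 1, `COc1cc2nnc(C(N)=O)c(Nc3ccc(C)cc3F)c2cc1N1CCN(S(C)(=O)=O)CC1`: 22 mL/min/kg
compound 2, `COc1cc2nnc(C(N)=O)c(Nc3ccc(C)cc3F)c2cc1N1CCN(C)CC1`: 12 mL/min/kg

Both values come from an ADME assay on the whole organism for pharmacokinetics, with Rattus norvegicus as the target, at a dose of 10 mg/kg by the oral route; a lower number here means slower removal, a higher number faster removal of the compound. Compound 2 gives 12 mL/min/kg, the lowest of the two numbers shown, and compound 1 gives 22 mL/min/kg, so the only measured step, a 1.8-fold lower number from compound 1 to compound 2 (0.26 log units; within the scatter), stays within the scatter.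

Compound 3, `COc1cc2nnc(C(N)=O)c(Nc3ccc(C)cc3F)c2cc1N1CCN(C(C)C)CC1`, has not yet been measured. It differs from compound 2 as follows: isopropyl in place of methyl on an amine nitrogen in a ring. Within the data shown here, no measured step involves an isopropyl group, and the one step that is known, a 1.8-fold lower number from compound 1 to compound 2 (0.26 log units; within the scatter), alters the same amine nitrogen in a ring by a different exchange and does not reach beyond the scatter. The account therefore rests on compound 2 alone, with no ground for expecting a step beyond the scatter in this assay in either direction. For compound 3 the estimate is 14 mL/min/kg, with a range of 7 mL/min/kg to 28 mL/min/kg. The step this estimate implies, a 1.2-fold higher number from compound 2 to compound 3 (0.07 log units; within the scatter), is expected to stay within the scatter.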

Compound 3, clearance: 17 mL/min/kg
Compound 3: middle estimate off by 1.2-fold (0.08 log units), on the low side; low and high end bracket the measured number.
By their numbers in this assay, from the lowest: compounds 2, 3 and 1 (each within the scatter of the next).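

In this assay, among these compounds, the exchange from 4-methylpiperazin-1-yl to 4-isopropylpiperazin-1-yl gives a 1.4-fold higher number from compound 2 to compound 3 (0.15 log units; within the scatter), so adding carbon to the group on this amine nitrogen in a ring produces no step that can be separated from the usual spread of repeated measurements. Among the compounds shown here, the exchange of methylsulfonyl for isopropyl at the same nitrogen reads the same way, with a 1.3-fold lower number from compound 1 to compound 3 (0.11 log units; within the scatter), and so methylsulfonyl, methyl and isopropyl now form a set of three groups at this position with no step among them beyond the scatter. Nothing measured here offers an explanation for this result.

Going by these compounds, it remains open whether a different kind of group on this nitrogen, such as a carboxylic acid, a hydroxyethyl chain or a plain amine hydrogen, would give a step beyond the scatter. On these data alone, it is equally open how the number would respond to changes elsewhere on the shared core, such as at the methoxy group or the primary amide, which all three compounds carry unchanged.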